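The source may report more compounds than this note shows. Statements on the series, on what has been measured and on what is new or still open speak of the compounds shown alone.

Compound 1 `O=c1cc(-c2cc(Br)c(Br)[nH]2)oc2ccccc12`: 1280 nM
Compound 2 `Cn1c(-c2cc(=O)c3ccccc3o2)cc(Br)c1Br`: 670 nM
Compound 3 `Cn1c(-c2cc(-c3ccccc3O)no2)cc(Br)c1Br`: 2450 nM

In a functional assay on KB403 cells (Homo sapiens) for cytotoxicity, read by MTT assay, with stated times of 6 h and 48 h (on this read-out higher numbers stand for weaker inhibition and lower numbers for stronger inhibition), these three compounds have been measured, and compound 4 `Oc1ccccc1-c1cc(-c2cc(Br)c(Br)[nH]2)on1` has not. Compound 4 stands to compound 3 as compound 1 stands to compound 2: in each pair the change is hydrogen in place of methyl on an aromatic nitrogen, and for the second pair this reads (hydrogen in place of methyl on an aromatic nitrogen). Both place descriptions agree word for word, so it is the same change. Where it is measured it made a 1.9-fold higher number from compound 2 to compound 1 (0.28 log units; within the scatter). How the core of compound 3 differs from the core of compound 2 is not broken down here. For compound 4 a step of a 1.4-fold higher number from compound 3 to compound 4 (0.15 log units; within the scatter) is expected, resting on the measured pair, because a 1.9-fold higher number from compound 2 to compound 1 (0.28 log units; within the scatter) stayed within the scatter. Compound 4 is therefore estimated at 3500 nM, with a likely range from 1500 nM to 8000 nM.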

Compound 4, half-maximal inhibitory concentration: 16400 nM
Estimate against measurement, compound 4: 4.7-fold (0.67 log units) below, and the stated range ends below it.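

In this assay, hydrogen in place of methyl on the aromatic nitrogen gave a 6.7-fold higher number from compound 3 to compound 4 (0.83 log units; beyond the scatter), and this step does not match the one measured on the other core: the same change on two cores in this assay, a 1.9-fold higher number (0.28 log units; within the scatter) from compound 2 to compound 1 and a 6.7-fold higher number (0.83 log units; beyond the scatter) from compound 3 to compound 4, 3.5-fold (0.54 log units) apart, beyond the scatter of two such steps. Within the data shown here, the size of this change therefore cannot be carried from one core to another, and only the step on the core of compound 3 lies beyond the scatter. Two pairs show that the step can depend on the core, but they do not show which part of the core matters or how the change would behave on a further core.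

The compounds shown leave open what an ethyl group or a longer chain on the aromatic nitrogen would do. They also leave open whether an amine in place of a bromo group would alter the step.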